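Phthalazinyl hydrazines and sulfonamides: the thiazolyl analogue

The source may hold more compounds than are shown below. What is called first, only, known or untested is meant among the compounds shown, and "the series" means these compounds.

Working notes on a set of phthalazin-1-yl hydrazine and amine derivatives tested in a functional assay on HeLa cells (Homo sapiens) for antiproliferative activity, read by sulforhodamine B assay, with a stated time of 72 h; a higher number here means a weaker inhibitor, a lower number a stronger inhibitor. Compound 1 `O=C1CS/C(=N/Nc2nncc3ccccc23)N1c1ccccc1` gives 56 nM. Compound 2 `COc1ccc(NC(=S)NNc2nncc3ccccc23)cc1` gives 38 nM. Compound 3 `Cc1cc(C)nc(NS(=O)(=O)c2ccc(Nc3nncc4ccccc34)cc2)n1` gives 3.5 nM, the lowest of the three numbers; its gap to compound 2 and its gap to compound 1 both lie beyond the usual scatter, so compound 3 is the strongest inhibitor of the measured set. The sulfonamide-bearing compound 3 thus stands apart from the two hydrazine-type compounds.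

Compound 4 `O=S(=O)(Nc1nccs1)c1ccc(Nc2nncc3ccccc23)cc1` is not yet measured. It differs from compound 3 in one place: 1,3-thiazol-2-yl in place of 4,6-dimethylpyrimidin-2-yl on a sulfonamide nitrogen. The sulfonamide linkage and the phthalazinyl-amino aryl part are kept.

Within the data shown here, no measured pair in the set shows this kind of exchange, so there is no step in this assay to lean on. Given that compound 3 gives 3.5 nM with the same sulfonamide framework, compound 4 is expected to land close to it, the step of a 1.7-fold higher number from compound 3 to compound 4 (0.23 log units; within the scatter) being small and possibly not beyond the scatter. The estimate for compound 4 is 6 nM, with a range from 2 nM to 20 nM.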

Compound 4, half-maximal inhibitory concentration: 15 nM
Compound 4: the middle estimate sits 2.5-fold (0.40 log units) below what was measured; low and high end bracket the measured number.
By their numbers in this assay, from the lowest: compound 3; then compound 4; then compounds 2 and 1 (each within the scatter of the next).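

Among these compounds, at the sulfonamide nitrogen, the attached ring is not interchangeable: in this assay, 1,3-thiazol-2-yl in place of 4,6-dimethylpyrimidin-2-yl gives a 4.3-fold higher number from compound 3 to compound 4 (0.63 log units; beyond the scatter), a modest loss and the first step that can be read at this position. The hydrogen-bond donor and acceptor counts of the two groups are the same, so those counts do not separate compound 3 from compound 4, although ring size, heavy-atom count and ring atoms all differ. Nothing available bears on the origin of this step.

Among the compounds shown here, the single exchange changes ring size, the two methyl groups and the ring atoms together, so their separate contributions remain open. An unsubstituted pyrimidin-2-yl group or a 4-methyl-1,3-thiazol-2-yl group at the same nitrogen would begin to separate them.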